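Swapping a methyl for a cyano on the benzyl ester ring

The source may report more compounds than this note shows. Statements on the series, on what has been measured and on what is new or still open speak of the compounds shown alone.

Measured compounds:
- compound 1, `COCCOC(=O)c1c(-c2ccc(OC)c(OC)c2)csc1N`: 57%
- compound 2, `COc1ccc(-c2csc(N)c2C(=O)OCc2ccccc2)cc1OC`: 100%
- compound 3, `COc1ccc(-c2csc(N)c2C(=O)OCc2ccc(C)cc2)cc1OC`: 50%

All three share one core and differ only in the ester group. In an assay on isolated protein for inhibition of protein kinase C zeta type (Homo sapiens), with stated times of 1 h and 2.5 min, tested at 30 uM (a higher number here means more inhibition at the concentration tested (going by the name of the read-out), a lower number less inhibition), compound 3 has the lowest of the three numbers; compound 1 lies within the scatter of it, while compound 2 sits far above it, as a number 50 percentage points lower from compound 2 to compound 3 (beyond the scatter) shows. The other steps are a number 43 percentage points higher from compound 1 to compound 2 (beyond the scatter) and a number 7 percentage points lower from compound 1 to compound 3 (within the scatter).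

Compound 4, `COc1ccc(-c2csc(N)c2C(=O)OCc2ccc(C#N)cc2)cc1OC`, has not yet been measured. It differs from compound 3 by cyano in place of methyl on an aromatic carbon. For the measured compounds named here, no measured step involves a cyano, so nothing bears on this change directly. Going by the values given here, the only step at this aromatic carbon, methyl in place of hydrogen, was large, which suggests that a change at this place can move the number strongly, in either direction. The expectation is therefore uncertain.

Compound 4 is expected to give about 55% in this assay, somewhere between 20% and 95%. This estimate for compound 4 means a step of a number 5 percentage points higher from compound 3 to compound 4 (within the scatter), essentially no expected change beyond the scatter, with wide uncertainty.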

Compound 4, a percentage reported as inhibition, at one concentration (the size of the read-out at that concentration, not a potency): 10%
The estimate for compound 4 lay 45 percentage points above the measured number; the measured number lies below the stated range.
By their numbers in this assay, from the lowest: compound 4; then compounds 3 and 1 (each within the scatter of the next); then compound 2.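

In this assay, for the compounds shown here, the earlier compounds showed only that adding a methyl to the benzyl ring of the ester lowers the number. The 4-cyanobenzyl ester now shows that the identity of the group at this ring carbon matters, as two different groups there give clearly different results (a number 40 percentage points lower from compound 3 to compound 4 (beyond the scatter)). The fall from the unsubstituted benzyl ester is larger than the one seen with methyl (a number 90 percentage points lower from compound 2 to compound 4 (beyond the scatter)), and the change of the whole ester group also lowers the number beyond the scatter (a number 47 percentage points lower from compound 1 to compound 4 (beyond the scatter)), which places compound 4 clearly below the other three. No measurement at hand offers a reason for these falls.

On these data alone, whether an amine or a carboxylic acid at this ring carbon would keep the number low remains open. So does whether a nitrile at another carbon of the ring would act the same way.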